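The source may hold more compounds than are shown below. What is called first, only, known or untested is meant among the compounds shown, and "the series" means these compounds.

Compound 1 `O=C(NO)c1ccc(CN(Cc2ccc(F)cc2)S(=O)(=O)c2c(F)c(F)c(F)c(F)c2F)cc1` gives 13 nM in an assay on isolated protein for inhibition of protein deacetylase HDAC6 (Homo sapiens), read by mobility shift assay; a higher number here means a weaker inhibitor, a lower number a stronger inhibitor. Compound 2 `O=C(NO)c1ccc(CN(Cc2ccc(F)cc2)S(=O)(=O)c2cc(F)c(F)c(F)c2F)cc1` gives 21 nM in this assay; it stands at the top of the two numbers, but a 1.6-fold higher number from compound 1 to compound 2 (0.21 log units; within the scatter) lies within the scatter, so the two are not distinguished. Compound 3 `O=C(NO)c1ccc(CN(Cc2ccccn2)S(=O)(=O)c2cc(F)c(F)c(F)c2F)cc1` differs from compound 2 by pyridin-2-yl in place of 4-fluorophenyl on a saturated chain carbon bound to a sulfonamide nitrogen. Among the compounds with values here, the only measured step, a 1.6-fold higher number from compound 1 to compound 2 (0.21 log units; within the scatter), concerns a fluoro on an aromatic carbon and not the saturated chain carbon bound to the sulfonamide nitrogen; no measured pair covers this change. The step from compound 2 to compound 3 is therefore expected to be a 1.4-fold higher number from compound 2 to compound 3 (0.15 log units; within the scatter), nothing beyond the scatter. Compound 3 is estimated at 30 nM, with a range of 10 nM to 90 nM.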

Compound 3, half-maximal inhibitory concentration: 6 nM
Beside the measured number, compound 3's estimate is 5.0-fold (0.70 log units) above it; measured number outside the range, below it.
By their numbers in this assay, from the lowest: compound 3; then compounds 1 and 2 (each within the scatter of the next).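

On the saturated chain carbon bound to a sulfonamide nitrogen, the group carried there matters in this assay: pyridin-2-yl in place of 4-fluorophenyl gives a 3.5-fold lower number from compound 2 to compound 3 (0.54 log units; beyond the scatter), a modest step but the only one in the series beyond the scatter. Within the data shown here, the swap removes a fluorine and brings in a ring nitrogen with a hydrogen-bond acceptor, and the single pair cannot separate these two parts of the change. No supporting measurement bears on the origin of this step.

Still open, going by these compounds, is whether unsubstituted phenyl, pyridin-3-yl or pyridin-4-yl would match pyridin-2-yl here. Also open, on these data alone, is whether a longer chain carrying the pyridine ring would keep the gain.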